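A few compounds are considered here, and "the series" means these few. Any claim that something is new, unique, unknown or untested is made for them only; others in the source may bear on it.

In an assay on mitochondria for binding affinity to carnitine O-palmitoyltransferase 1, liver isoform (Rattus norvegicus) (a higher number here means a weaker inhibitor, a lower number a stronger inhibitor), compound 3 `CCCCCCCCOC(=O)N[C@@H](CC(=O)[O-])C[N+](C)(C)C` gives 9500 nM, the highest of the three numbers measured; compound 2 `CCCCCCCCCCCS(=O)(=O)N[C@H](CC(=O)[O-])C[N+](C)(C)C` gives 6000 nM and compound 1 `CCCCCCCCCCCS(=O)(=O)N[C@@H](CC(=O)[O-])C[N+](C)(C)C` gives 800 nM. Compound 4 `CCCCCCCCOC(=O)N[C@H](CC(=O)[O-])C[N+](C)(C)C` differs from compound 3 by the two compounds have the same atoms and bonds and differ only in configuration as drawn: 1 of 1 stereo elements differ; a stereocentre at a saturated chain carbon is drawn S in compound 3 and R in compound 4, with nothing leaving or entering. Within the data shown here, the single measured step of this kind is a 7.5-fold higher number from compound 1 to compound 2 (0.88 log units; beyond the scatter), and it bears directly on the present change because the fact that compounds 1 and 2 differ only in the configuration as drawn is the same kind of difference as that between compound 3 and compound 4. The step is therefore expected to run in the same direction, with the number rising by about a 6.3-fold higher number from compound 3 to compound 4 (0.80 log units; beyond the scatter), beyond the scatter. In this assay compound 4 is estimated at 60000 nM, with a range of 20000 nM to 200000 nM.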

Compound 4, half-maximal inhibitory concentration: > 300000 nM
Compound 4: no number, only a limit; the forecaster's own chance of this, stated with the estimate: 25%; middle value at least 5.0-fold (0.69 log units) from the limit.
By their numbers in this assay, from the lowest: compound 1; then compounds 2 and 3 (each within the scatter of the next). At a limit, above all of these: compound 4.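

Among these compounds, the preference for the S drawing at this saturated chain carbon, until now seen only in compounds 1 and 2, recurs in a second pair with a different chain and link: an at least 31-fold higher number from compound 3 to compound 4 (1.49 log units; beyond the scatter). In this assay compound 4 gives > 300000 nM, which is a limit of the assay and not a number. Within these two pairs, the compound drawn R is the weaker inhibitor in each case.

From the compounds shown here alone, whether the same preference holds with an amide or a urea as the link stays open. Among the compounds shown here, the limit also leaves open whether this step is larger than the one between compounds 1 and 2.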